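A few compounds are considered here, and "the series" means these few. Any claim that something is new, unique, unknown or untested is made for them only; others in the source may bear on it.

Compound 1 `C/C(=N\Nc1nc(-c2ccccn2)cs1)c1ccc(Cl)c(Cl)c1`: 10100 nM
Compound 2 `C/C(=N\Nc1nc(-c2ccc(F)cc2)cs1)c1ccc(Cl)c(Cl)c1`: > 50000 nM, a limit
Compound 3 `C/C(=N\Nc1nc(-c2ccc(Cl)cc2Cl)cs1)c1ccc(Cl)c(Cl)c1`: > 50000 nM, a limit

These results come from an ADME assay on J774 cells (Mus musculus) for cytotoxicity, read by resazurin assay, with a stated time of 72 h; on this read-out lower numbers stand for higher toxicity in this test and higher numbers for lower toxicity in this test. Compound 3 gives > 50000 nM, which is a limit and not a number. It therefore stands at the limit of > 50000 nM in this assay, at which 2 of the 3 values shown sit.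

Compound 4 `C/C(=N\Nc1nc(-c2ccc(Cl)c(Cl)c2)cs1)c1ccc(Cl)c(Cl)c1` has the same atoms as compound 3, joined differently: 3,4-dichlorophenyl in place of 2,4-dichlorophenyl on an aromatic carbon. In it, 3,4-dichlorophenyl takes the place of 2,4-dichlorophenyl on an aromatic carbon, next to the ring nitrogen.

For the measured compounds named here, no measured step makes this exact change. The nearest evidence comes from replacing pyridin-2-yl: an at least 4.9-fold higher number from compound 1 to compound 2 (0.69 log units; beyond the scatter), and an at least 4.9-fold higher number from compound 1 to compound 3 (0.69 log units; beyond the scatter). Both steps are at least modest, and both end at the limit. The step between the two substituted phenyl compounds gives no size: a step that the two limits leave unreadable from compound 2 to compound 3.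

Compound 4 also carries a dichlorophenyl group, as compound 3 does, and compound 3 gives > 50000 nM. No step beyond the scatter is therefore expected in this assay, and the result may well be reported only as a limit. The expected change is an at least 1.1-fold lower number from compound 3 to compound 4 (0.04 log units; that floor lies within the scatter). For compound 4, the estimated value is 45000 nM, with an expected range from 18000 nM to 60000 nM.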

Compound 4, half-maximal cytotoxic concentration: > 50000 nM
Compound 4 ended at the assay's limit; the forecaster's own chance of this, stated with the estimate: 65%; middle value at least 1.1-fold (0.04 log units) from the limit.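

In this assay, compound 4 sits at a limit and not at a number, alongside compound 2 and compound 3, so the placing of the two chlorines on this phenyl ring, on the aromatic carbon next to the ring nitrogen, shows no readable effect: the limit of > 50000 nM in this assay, at which 3 of the 4 values shown sit. The steps from compound 2 and from compound 3 to compound 4 cannot be read, so any difference between the 2,4-dichlorophenyl and 3,4-dichlorophenyl groups stays hidden in this test. Replacing pyridin-2-yl with 3,4-dichlorophenyl gives an at least 4.9-fold higher number from compound 1 to compound 4 (0.69 log units; beyond the scatter), which makes this the third substituted phenyl group to end at the limit and leaves compound 1 as the only compound shown with a number.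

Going by these compounds, how far compound 2, compound 3 and compound 4 lie past the limit stays open, and so does any order among them. Also open, on these data alone, is whether a phenyl ring carrying an amine or a carboxylic acid at this place would stay at the limit or come down to a number, as compound 1 does.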